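Cytotoxicity of Two Small Chain Extensions

This account rests on a few compounds, and the source may have more. Where it says the series, first, only, none or still open, it means among the compounds named here.

Compound 1 `CCNC(=O)c1cc(N)c(Nc2ccc(C#N)cc2)cc1Oc1c(C)cc(CCC#N)cc1C` and compound 2 `Cc1cc(CCC#N)cc(C)c1Oc1cc(Nc2ccc(C#N)cc2)c(N)cc1C(=O)NC(C)C` share one core, and compound 2 carries methyl in place of hydrogen on a saturated chain carbon bound to an amide-type nitrogen and a saturated chain carbon. In an ADME assay on TZM cells (Homo sapiens) for cytotoxicity, with a stated time of 1 days (a lower number here means that less compound is tolerated, a higher number that more compound is tolerated), compound 1 gives 105000 nM, while compound 2 gives 184000 nM, the step being a 1.8-fold higher number from compound 1 to compound 2 (0.24 log units; within the scatter). Compound 3 `COCc1cc(N)c(Nc2ccc(C#N)cc2)cc1Oc1c(C)cc(CCC#N)cc1C` has a different core, the difference being (methoxymethyl in place of ethylcarbamoyl on an aromatic carbon). In this assay compound 3 reaches only a limit, > 200000 nM, which is the limit of > 200000 nM in this assay, at which 1 of the 3 values shown sits. Compound 4 `CCOCc1cc(N)c(Nc2ccc(C#N)cc2)cc1Oc1c(C)cc(CCC#N)cc1C` is compound 3 with methyl in place of hydrogen on a saturated chain carbon bound to an oxygen on a saturated carbon. This is the same kind of change as that made between compound 1 and compound 2, though the surroundings differ: there the carbon is bound to an amide-type nitrogen and a saturated chain carbon, here to an oxygen on a saturated carbon. For compound 4 the step is expected to be a step that the limit leaves unreadable from compound 3 to compound 4, resting on the measured step of a 1.8-fold higher number from compound 1 to compound 2 (0.24 log units; within the scatter). Compound 4 is therefore estimated at 260000 nM.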

Compound 4, half-maximal cytotoxic concentration: 194000 nM
Estimate against measurement, compound 4: 1.3-fold (0.13 log units) above; low and high end bracket the measured number.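

Whether the methyl step carries over from the core of compound 1 to the core of compound 3 stays undecided: the same change on two cores in this assay, a 1.8-fold higher number (0.24 log units; within the scatter) from compound 1 to compound 2 and an at least 1.0-fold lower number (0.01 log units; that floor lies within the scatter) from compound 3 to compound 4; the limit leaves it open whether they differ Compound 3 has only a limit, > 200000 nM and no exact number. The step can therefore be given only as an at least 1.0-fold lower number from compound 3 to compound 4 (0.01 log units; that floor lies within the scatter) and no more closely than that. In this assay, ethoxymethyl in place of the carbamoyl groups gives a 1.1-fold higher number from compound 2 to compound 4 (0.02 log units; within the scatter) and a 1.8-fold higher number from compound 1 to compound 4 (0.27 log units; within the scatter), so these two steps are readable and small, but they test a different change and show neither transfer nor its failure.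

The compounds shown leave open how a longer chain, such as propoxymethyl, would read in this assay. As far as these compounds go, an amine in place of ethoxymethyl also remains open.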